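A few compounds are considered here, and "the series" means these few. Any claim that something is new, unique, unknown or untested is made for them only; others in the source may bear on it.

Working notes on the series. Two compounds carry numbers in a functional assay on the whole organism for inhibition, with Rattus norvegicus as the target, at a dose of 10 mg/kg by the oral route; a higher number here means a stronger effect of the compound at the dose given, a lower number a weaker effect. Compound 1 `COc1cc(C)nc(C(=O)Nc2nn[nH]n2)c1` gives 20% in this assay. Compound 2 `COc1cccnc1C(=O)Nc1nn[nH]n1` gives 0% in this assay, the lowest of the two numbers, with compound 1 as its nearest neighbour at a distance beyond the scatter. Going by the values given here, no step between measured compounds that differ in one place is available, so the pair tells only what its two values show.

Compound 3 `Cc1cccnc1C(=O)Nc1nn[nH]n1` is not yet measured. It differs from compound 2 by methyl in place of methoxy on an aromatic carbon. Nothing in the measured pair isolates this change, so the expected step is read from the structural change alone: a small shift, if any, beyond the scatter, with a slight lean upward from the floor at which compound 2 sits. The step from compound 2 to compound 3 in this assay is estimated at a number 8 percentage points higher from compound 2 to compound 3 (within the scatter). Compound 3 is therefore expected to give about 8% in this assay, in a range from 0% to 25%.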

Compound 3, a percentage reported as inhibition, in the whole organism at one dose (the size of the read-out at that dose, not a potency): 69%
Compound 3: the middle estimate sits 61 percentage points below what was measured; measured number above the stated range.
By their numbers in this assay, from the lowest: compound 2; then compound 1; then compound 3.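

In this assay, the aromatic carbon two atoms from the ring nitrogen, ortho to a group of 8 heavy atoms, proves far from indifferent to the group it carries: methyl in place of methoxy reads as a number 69 percentage points higher from compound 2 to compound 3 (beyond the scatter). Going by these compounds alone, this is the first single change that can be read on its own, and it shows that a swap of only methoxy for methyl can lift the effect at this dose clear of the floor at which compound 2 sits. Nothing measured bears on why the step is so large.

Going by these compounds, how an ethyl group, a chlorine atom or an amine on this carbon would read in this assay remains open. Also open is whether the step between compound 2 and compound 3 holds at doses other than the single one shown.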